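A few compounds are considered here, and "the series" means these few. Any claim that something is new, unique, unknown or untested is made for them only; others in the source may bear on it.

Compound 1 `Cc1ccc(-c2cn(/N=C/c3cc4cc(C)ccc4nc3Cl)c(N)n2)cc1` gives 25200 nM in a functional assay on DLD-1 cells (Homo sapiens) for cytotoxicity, read by MTT assay, with a stated time of 48 h; a lower number here means a stronger inhibitor, a higher number a weaker inhibitor. Compound 2 `Cc1ccc2nc(Cl)c(/C=N/n3cc(-c4ccc(Cl)cc4)nc3N)cc2c1`, carrying chloro in place of methyl on an aromatic carbon, gives 38900 nM in this assay; the step is a 1.5-fold higher number from compound 1 to compound 2 (0.19 log units; within the scatter). Of the two numbers in hand, compound 2 holds the higher one, but that gap lies within the scatter and so separates nothing.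

Compound 3 `Cc1ccc2nc(Cl)c(/C=N/n3cc(-c4cccc5ccccc45)nc3N)cc2c1` differs from compound 2 by naphthalen-1-yl in place of 4-chlorophenyl on an aromatic carbon. Among the measured compounds shown here, no measured step replaces one aromatic group by another with a different ring count; the only step available, a 1.5-fold higher number from compound 1 to compound 2 (0.19 log units; within the scatter), changes a substituent on that same ring and stays within the scatter. Nothing in the data therefore supports a shift beyond the scatter in this assay in either direction, and the expected step is a 1.3-fold lower number from compound 2 to compound 3 (0.11 log units; within the scatter). Compound 3 is estimated to give about 30000 nM in this assay, with a range from 10000 nM to 90000 nM.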

Compound 3, half-maximal inhibitory concentration: 8300 nM
Beside the measured number, compound 3's estimate is 3.6-fold (0.56 log units) above it; the whole stated range lies above it.
By their numbers in this assay, from the lowest: compound 3; then compounds 1 and 2 (each within the scatter of the next).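

At the aromatic carbon of the five-membered aromatic ring with 2 nitrogen, next to the ring nitrogen, naphthalen-1-yl gives a shift in this assay against both phenyl partners: a 4.7-fold lower number from compound 2 to compound 3 (0.67 log units; beyond the scatter) and a 3.0-fold lower number from compound 1 to compound 3 (0.48 log units; beyond the scatter) point the same way. Chloro in place of methyl on the phenyl ring, a 1.5-fold higher number from compound 1 to compound 2 (0.19 log units; within the scatter), separated nothing, so exchanging the whole aromatic group is the first change at this position to move the number beyond the scatter. No measurement in hand bears on the reason for this shift.

Whether the shift follows from the second six-membered ring itself or from how that ring is attached stays open, since naphthalen-2-yl is not among the compounds shown. Also open, from the compounds shown here alone, is how this position responds to a pyridinyl group, a benzyl group or a simple amine.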